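The compounds below may be only part of what the source reports. "The series", "measured", "known", "first", "only" and "open" are said of these compounds alone.

Measured compounds in a functional assay on Ehrlich cells (Mus musculus) for antiproliferative activity, read by trypan blue exclusion, with a stated time of 2 h, tested at 25 ug/mL; a lower number here means a weaker effect, a higher number a stronger effect of the compound at the concentration tested:
compound 1 `COc1ccccc1C1C(C#N)=C(N)N(c2ccc(S(N)(=O)=O)cc2)C2=C1C(=O)CCC2` — 0%
compound 2 `COc1cc(CC2C(C#N)=C(N)N(c3ccc(S(N)(=O)=O)cc3)C3=C2C(=O)CCC3)ccc1O` — 50%

Compound 2 stands highest of the two numbers, with compound 1 far below it. Within the data shown here, the only step measured, a number 50 percentage points higher from compound 1 to compound 2 (beyond the scatter), put a 4-hydroxy-3-methoxybenzyl group in place of 2-methoxyphenyl on the saturated ring carbon. Compound 3 `N#CC1=C(N)N(c2ccc(S(N)(=O)=O)cc2)C2=C(C(=O)CCC2)C1c1ccc([N+](=O)[O-])cc1` reverses that kind of change: 4-nitrophenyl in place of 4-hydroxy-3-methoxybenzyl on a saturated ring carbon. On these data alone, an aryl ring sits directly on that carbon again, as in compound 1, so a sizeable fall is expected in this assay, though the nitro substituent is untested. Compound 3 is therefore estimated at 15%, between 0% and 45%. That estimate means an expected step of a number 35 percentage points lower from compound 2 to compound 3 (beyond the scatter).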

Compound 3, a percentage reported as activity, at one concentration (the size of the read-out at that concentration, not a potency): 80%
For compound 3 the middle estimate is 65 percentage points below the measured one; measured number above the stated range.
By their numbers in this assay, from the lowest: compound 1; then compound 2; then compound 3.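

At the saturated ring carbon, in this assay the 4-nitrophenyl group gave a number 30 percentage points higher from compound 2 to compound 3 (beyond the scatter) and so the 4-hydroxy-3-methoxybenzyl group is not needed for a high read-out. Against 2-methoxyphenyl it gave a number 80 percentage points higher from compound 1 to compound 3 (beyond the scatter) and so a phenyl ring on this carbon does not by itself set the read-out, which here differs with the ring's substituent. Nothing given here accounts for these differences. On these data alone, whether the nitro group or its place on the ring matters remains open, as does the outcome with 4-methoxyphenyl, 2-nitrophenyl or a 4-carboxyphenyl group.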